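Aldehyde series: methylsulfanyl to methylsulfonyl in compound 3

The source may report more compounds than this note shows. Statements on the series, on what has been measured and on what is new or still open speak of the compounds shown alone.

In a functional assay on HeLa cells (Homo sapiens) for cytotoxicity, read by XTT assay (on this read-out lower numbers stand for higher toxicity in this test and higher numbers for lower toxicity in this test), compound 1 `CC(=O)N[C@@H](CC(C)C)C(=O)N[C@@H](CC(C)C)C(=O)N[C@H](C=O)CCS(C)(=O)=O` gives only a limit of > 224 uM and no number. Going by the values given here, compound 2 `CSCC[C@@H](C=O)NC(=O)[C@H](CC(C)C)NC(=O)OCc1ccccc1` gives 83 uM as the only actual number so far. Compound 3 `CC(C)C[C@H](NC(=O)OCc1ccccc1)C(=O)N[C@H](C=O)CCS(C)(=O)=O` carries methylsulfonyl in place of methylsulfanyl on a saturated chain carbon, three bonds along the chain from an amide-type nitrogen and a carbonyl carbon and is still unmeasured. Compound 1 also carries methylsulfonyl but differs elsewhere, and its limit of > 224 uM is the only hint of a shift towards lower toxicity in this assay here. The expected step of a 1.7-fold higher number from compound 2 to compound 3 (0.23 log units; within the scatter) is modest and close to the usual scatter. For compound 3 the estimate is 140 uM with an expected range of 60 uM to 300 uM in this read-out.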

Compound 3, half-maximal toxic concentration: > 224 uM
Compound 3 gave a limit, no number; the forecaster's own chance of this, stated with the estimate: 25%; middle value at least 1.6-fold (0.20 log units) from the limit.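

In this assay, going by these compounds alone, the change from methylsulfanyl to methylsulfonyl on a saturated chain carbon gives the first single-change reading, with an at least 2.6-fold higher number from compound 2 to compound 3 (0.43 log units; beyond the scatter) as its step. Compound 3 gives a limit and not a number, so this step is only a lower bound: the limit of > 224 uM in this assay, at which 2 of the 3 values shown sit. The step between compound 1 and compound 3 cannot be read. On these data alone, the true size of the step stays open, as does whether a carboxylic acid or an amine at this place would give a number in this read-out.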